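The source may hold more compounds than are shown below. What is called first, only, known or untested is meant among the compounds shown, and "the series" means these compounds.

Measured so far in a functional assay on MC-38 cells (Mus musculus) for antiproliferative activity, read by CCK-8 assay, with a stated time of 48 h; a higher number here means a weaker inhibitor, a lower number a stronger inhibitor:
- compound 1 `COc1ccc(/C=C\c2cc(OC)c(OC)c(OC)c2)cc1OCc1ccc(CN[C@H](C(=O)O)[C@H](C)O)cc1` gives > 10000 nM (a limit, not a number)
- compound 2 `COc1ccc(/C=C\c2cc(OC)c(OC)c(OC)c2)cc1OCc1ccc(CNCCO)cc1` gives 1200 nM
- compound 3 `COc1ccc(/C=C\c2cc(OC)c(OC)c(OC)c2)cc1OCc1ccc(CN2CCCCC2C(=O)NCCNC(=O)OC(C)(C)C)cc1` gives 1900 nM

Compound 1 stands at the limit of > 10000 nM in this assay, at which 1 of the 3 values shown sits, and that is a limit, not a number.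

Compound 4 `COc1ccc(/C=C\c2cc(OC)c(OC)c(OC)c2)cc1OCc1ccc(CNCCNC(C)=O)cc1` keeps the core of compound 1 but carries 2-acetamidoethyl in place of 1-carboxy-2-hydroxypropyl on an amine nitrogen and nothing else changes. Going by the values given here, one measured step bears directly on this swap. The step of an at least 8.3-fold lower number from compound 1 to compound 2 (0.92 log units; beyond the scatter) removes the same 1-carboxy-2-hydroxypropyl and puts 2-hydroxyethyl on that nitrogen. A step of similar size, toward a lower number, is therefore expected for compound 4 in this assay and it would bring compound 4 close to compound 2 at 1200 nM as its nearest measured relative. The expected change is an at least 6.6-fold lower number from compound 1 to compound 4 (0.82 log units; beyond the scatter) according to this estimate. The estimated value for compound 4 is 1500 nM with an expected range from 500 nM to 4500 nM around it.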

Compound 4, half-maximal inhibitory concentration: 1800 nM
The estimate for compound 4 lay 1.2-fold (0.08 log units) below the measured number, and the stated range covers the measured number.
By their numbers in this assay, from the lowest: compounds 2, 4 and 3 (each within the scatter of the next). At a limit, above all of these: compound 1.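

Two different groups on the amine nitrogen now sit well clear of compound 1. In this assay, as far as these compounds go, 2-acetamidoethyl in place of 1-carboxy-2-hydroxypropyl gives an at least 5.5-fold lower number from compound 1 to compound 4 (0.74 log units; beyond the scatter) and so shows that the earlier gain was not unique to 2-hydroxyethyl, though compound 1 has only a limit, not a number, and the full size of this step stays unknown. Acetamido in place of hydroxy on the chain gives a 1.5-fold higher number from compound 2 to compound 4 (0.18 log units; within the scatter), so this assay does not separate these two chain ends.

Open, from the compounds shown here alone, is whether a plain 2-aminoethyl or a longer chain such as 3-hydroxypropyl would fit with compound 2 and compound 4. Also open, going by these compounds, is which part of 1-carboxy-2-hydroxypropyl matters, a question that a simple carboxymethyl on the same nitrogen could help to settle.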